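The source may hold more compounds than are shown below. What is called first, only, known or untested is meant among the compounds shown, and "the series" means these compounds.

Measured compounds:
- compound 1, `Cc1nn(-c2ncnc3nc[nH]c23)c2c1C(c1ccc(F)cc1Cl)CC(=O)N2`: 280 nM
- compound 2, `CCC(C(=O)NC1CC(=O)Nc2c1c(C)nn2-c1ncnc2nc[nH]c12)c1ccccc1`: 79 nM
- compound 3, `Cc1cc(C)nc(-n2nc(C)c3c2NC(=O)CC3c2ccc(F)cc2F)n1`: > 10000 nM

In a functional assay on HEK293 cells for agonist activity at G-protein coupled receptor 39 (Homo sapiens), read by scintillation proximity assay and inositol phosphate accumulation, with a stated time of 75 min (on this read-out higher numbers stand for an effect only at larger amounts of compound and lower numbers for an effect already at smaller amounts), compound 1 gives 280 nM. Of the two numbers recorded, that of compound 1 is the higher: compound 2 gives 79 nM, a lower number by a margin beyond the usual scatter. Compound 3 gives > 10000 nM, which is not a number but (the limit of > 10000 nM in this assay, at which 1 of the 3 values shown sits).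

Compound 4, `Cc1nn(-c2ncnc3nc[nH]c23)c2c1C(C(=O)NCc1ccccc1)CC(=O)N2`, has not yet been measured. It differs from compound 1 in one place: benzylcarbamoyl in place of 2-chloro-4-fluorophenyl on a saturated ring carbon. Among the compounds with values here, no measured pair shows this exact change, so its size can only be estimated. Compound 2 carries a carbonyl-bearing group rather than an aryl ring at that saturated ring carbon, and with 79 nM it shows that such a replacement need not raise the number. The aryl ring of compound 1 is lost, however, and the new group is a different kind of amide, so the expected step of a 2.1-fold higher number from compound 1 to compound 4 (0.33 log units; beyond the scatter) is small and upward, uncertain in direction. Compound 4 is estimated to give 600 nM, within a range from 120 nM to 3000 nM.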

Compound 4, half-maximal effective concentration: 2930 nM
Compound 4: the middle estimate sits 4.9-fold (0.69 log units) below what was measured, within the range that was stated.
By their numbers in this assay, from the lowest: compound 2; then compound 1; then compound 4. At a limit, above all of these: compound 3.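

The saturated ring carbon of the shared core is clearly sensitive to what it carries: in this assay, benzylcarbamoyl in place of 2-chloro-4-fluorophenyl gives a 10-fold higher number from compound 1 to compound 4 (1.02 log units; beyond the scatter), a large step. Both groups bring one six-membered aromatic ring of carbon only, so having such a ring in the group at this carbon does not by itself keep the number low. The change also adds a carbonyl and an amide hydrogen and removes the chlorine and fluorine, and nothing measured here says which of these differences accounts for the step.

The compounds shown leave open how the number would move with a plain phenyl at this carbon, which would test the chlorine and fluorine separately. They also leave open what a smaller methylcarbamoyl, a carboxylic acid or an amine would do there.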